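From an amide to a longer ester: expecting compound 4

The compounds below may be only part of what the source reports. "The series", "measured", "known", "first", "only" and "open" are said of these compounds alone.

Compound 1 `COc1ccc(N(C)c2nc(C)nc3ccccc23)cc1C(=O)OCCC[Se]C#N`: 250 nM
Compound 2 `COc1ccc(N(C)c2nc(C)nc3ccccc23)cc1C(=O)NCC[Se]C#N`: 187 nM
Compound 3 `COc1ccc(N(C)c2nc(C)nc3ccccc23)cc1OCCN`: 122 nM

All three values come from a functional assay on A549 cells (Homo sapiens) for inhibition, read by MTT assay, with a stated time of 48 h; on this read-out lower numbers stand for stronger inhibition and higher numbers for weaker inhibition. Compound 2 holds the middle of the three numbers, but it is not separated from either neighbour: a 1.3-fold lower number from compound 1 to compound 2 (0.13 log units; within the scatter), and a 1.5-fold lower number from compound 2 to compound 3 (0.19 log units; within the scatter). Only the outer pair differs by more than the scatter, and modestly: a 2.0-fold lower number from compound 1 to compound 3 (0.31 log units; beyond the scatter).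

The next compound is compound 4 `COc1ccc(N(C)c2nc(C)nc3ccccc23)cc1C(=O)OCCCCC[Se]C#N`, which changes what sits on the carbonyl carbon of compound 2: a group of 9 heavy atoms (6 carbon, 1 nitrogen, 1 oxygen, 1 selenium; no ring) in place of a group of 6 heavy atoms (3 carbon, 2 nitrogen, 1 selenium; no ring), on a carbonyl carbon. The amide becomes an ester with a longer chain. The closest guide is compound 1, also an ester, whose small step to compound 2 is given above. Among the measured compounds shown here, no measured pair shows what a longer chain does on its own, so a large step in this assay has no support. The expected change is a 1.2-fold higher number from compound 2 to compound 4 (0.09 log units; within the scatter), a slight rise at most. The estimate for compound 4 is 230 nM, with an expected range from 90 nM to 600 nM.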

Compound 4, half-maximal inhibitory concentration: 592 nM
Compound 4: middle estimate off by 2.6-fold (0.41 log units), on the low side; measured number inside the range.
By their numbers in this assay, from the lowest: compounds 3, 2 and 1 (each within the scatter of the next, the first and the last beyond it); then compound 4.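

Among the compounds shown here, compounds 1 and 4 are both esters and differ only in chain length, so they give the first direct reading of what lengthening this chain does: in this assay the longer chain brings a 2.4-fold higher number from compound 1 to compound 4 (0.37 log units; beyond the scatter), a modest loss of inhibition. The other step, a 3.2-fold higher number from compound 2 to compound 4 (0.50 log units; beyond the scatter), also points towards weaker inhibition, but it changes the amide to an ester and lengthens the chain at once, so it cannot be divided between those two changes. Nothing measured here explains the rise.

Two ester chain lengths give no trend, so a still longer chain would be needed to show whether the numbers keep rising. An amide carrying the longer chain of compound 4 would show whether the amide and ester links behave alike at that length.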